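Series notes: swapping the triazole substituent in a bromoquinoline set

This account rests on a few compounds, and the source may have more. Where it says the series, first, only, none or still open, it means among the compounds named here.

Measured compounds:
- compound 1, `CCCCCCCc1cn(C(c2ccccc2)c2cc3cc(Br)ccc3nc2OC)nn1`: 9.7%
- compound 2, `CCCCCCc1cn(C(c2ccccc2)c2cc3cc(Br)ccc3nc2OC)nn1`: -0.97%
- compound 3, `COc1nc2ccc(Br)cc2cc1C(c1ccccc1)n1cc(-c2ccccc2F)nn1`: 14.1%

In an ADME assay on HeLa cells (Homo sapiens) for cytotoxicity, read by sulforhodamine B assay, with a stated time of 48 h, tested at 10 uM (on this read-out higher numbers stand for more inhibition at the one concentration tested (going by the name of the read-out) and lower numbers for less inhibition), compound 3 holds the highest of the three numbers, though its gap to compound 1 lies within the scatter, a number 4.4 percentage points higher from compound 1 to compound 3 (within the scatter), and only its gap to compound 2 lies beyond it, a number 15.1 percentage points higher from compound 2 to compound 3 (beyond the scatter). Compound 4 is `COc1nc2ccc(Br)cc2cc1C(c1ccccc1)n1cc(CCCO)nn1` and is not yet measured in this assay. The change from compound 3 is 3-hydroxypropyl in place of 2-fluorophenyl on an aromatic carbon.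

Going by the values given here, two measured steps touch the same aromatic carbon, both moving from a plain chain to 2-fluorophenyl: a number 4.4 percentage points higher from compound 1 to compound 3 (within the scatter) and a number 15.1 percentage points higher from compound 2 to compound 3 (beyond the scatter). Read backwards they say that taking the 2-fluorophenyl away in favour of a chain gave no rise and at most a modest fall. The step between the two chains themselves, a number 10.7 percentage points lower from compound 1 to compound 2 (beyond the scatter), was also modest. Among the compounds with values here, no measured step carries a hydroxyl on the chain, so the 3-hydroxypropyl has no direct precedent here. A modest fall or no step beyond the scatter is therefore expected for compound 4, a number 9.1 percentage points lower from compound 3 to compound 4 (within the scatter). The value of compound 4 in this assay is estimated at 5%, within -8% to 18%.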

Compound 4, a percentage reported as inhibition, at one concentration (the size of the read-out at that concentration, not a potency): 11.3%
Compound 4: middle estimate off by 6.3 percentage points, on the low side, within the range that was stated.
By their numbers in this assay, from the lowest: compound 2; then compounds 1, 4 and 3 (each within the scatter of the next).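

Going by these compounds alone, at the aromatic carbon of the five-membered aromatic ring with 3 nitrogen, this assay gives the first reading for a chain carrying a hydroxyl, and replacing 2-fluorophenyl with 3-hydroxypropyl gives a number 2.8 percentage points lower from compound 3 to compound 4 (within the scatter) with no shift beyond the scatter. The same chain also reads level with the heptyl compound, a number 1.6 percentage points higher from compound 1 to compound 4 (within the scatter) and sits clear of the hexyl compound, a number 12.3 percentage points higher from compound 2 to compound 4 (beyond the scatter) in a step of modest size. Losing the aromatic ring at this position therefore need not lower the number, as compounds 1 and 4 show, while compound 2 goes against that reading.

On these data alone, whether a plain propyl, or an amine or carboxylic acid at the chain end, would read differently from 3-hydroxypropyl stays open. No supporting data explain the size of any of these steps.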